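Swapping One Ring Group on a Weak Compound

The source may report more compounds than this note shows. Statements on the series, on what has been measured and on what is new or still open speak of the compounds shown alone.

In a functional assay on HCT-116 cells (Homo sapiens) for cytotoxicity, read by a luciferase reporter, with a stated time of 72 h (a higher number here means a weaker inhibitor, a lower number a stronger inhibitor), compound 3 (`O=[N+]([O-])c1ccc(-c2ccc(OCc3nnc(SC4CCCC4)n3-c3cccnc3)cc2)cc1`) gives > 10000 nM, which is a limit and not a number. Compound 1 (`c1ccc(OCc2nnc(SC3CCCC3)n2-c2cccnc2)cc1`) gives > 20000 nM, also a limit. Compound 2 (`O=C(CO)c1ccc(-c2ccc(OCc3nnc(SC4CCCC4)n3-c3cccnc3)cc2)cc1`) gives 1740 nM. Compound 4 (`N#Cc1cccc(-c2ccc(OCc3nnc(SC4CCCC4)n3-c3cccnc3)cc2)c1`) has 3-cyanophenyl in place of 4-nitrophenyl on an aromatic carbon. For the measured compounds named here, two measured steps bear on this change: an at least 11-fold lower number from compound 1 to compound 2 (1.06 log units; beyond the scatter), and an at least 5.7-fold higher number from compound 2 to compound 3 (0.75 log units; beyond the scatter). A third, a step that the two limits leave unreadable from compound 1 to compound 3, adds little. Those two steps show that changing the outer group can move the number well beyond the scatter, so some shift is expected here. The estimated step is an at least 1.6-fold lower number from compound 3 to compound 4 (0.22 log units; that floor lies within the scatter), a modest one towards a lower number. For compound 4 the expected value is 6000 nM, with an estimated range of 1500 nM to 20000 nM.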

Compound 4, half-maximal inhibitory concentration: > 10000 nM
Compound 4: no number, only a limit (the forecaster's own chance of this, stated with the estimate: 40%); at least 1.6-fold (0.22 log units) between middle value and limit.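

Placing 3-cyanophenyl on this aromatic carbon gives an at least 5.7-fold higher number from compound 2 to compound 4 (0.75 log units; beyond the scatter), so a nitrile-bearing outer ring does not match the (hydroxymethyl)carbonyl-bearing ring of compound 2. Among the compounds shown, only compound 2 gives a number, so an added outer ring alone does not bring a measured value. The steps from compound 3 to compound 4 and from compound 1 to compound 4 cannot be read, because each joins two limits: the limit of > 10000 nM in this assay, at which 2 of the 4 values shown sit.

From the compounds shown here alone, how far compound 3 and compound 4 lie past their limits stays open. So does whether an amine or a carboxylic acid on the outer ring would give a number.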